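The source may report more compounds than this note shows. Statements on the series, on what has been measured and on what is new or still open speak of the compounds shown alone.

Measured so far in a functional assay on T98G cells (Homo sapiens) for inhibition, read by colorimetric assay and MTT assay, with a stated time of 72 h; a lower number here means a stronger inhibitor, a higher number a weaker inhibitor:
- Compound 1 `COc1ccc2c(c1)-c1cnc(n1C)OCCCCCCCCO2`: 68000 nM
- Compound 2 `Cn1c(-c2ccccc2O)cnc1S(=O)(=O)c1ccccc1`: > 100000 nM

Both compounds are weak on these numbers. Compound 2 gives > 100000 nM, which is a limit of this assay and not a number. The same holds for the pair as a whole: the limit of > 100000 nM in this assay, at which 1 of the 2 values shown sits.

Compound 3 `C=CCCOc1ccccc1-c1cnc(S(=O)(=O)c2ccccc2)n1C` is compound 2 with but-3-en-1-yl in place of hydrogen on an oxygen on an aromatic ring, that is, hydroxy to (but-3-en-1-yl)oxy.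

For the measured compounds named here, no step between measured compounds is available to size this change, so the expectation rests on little. Compound 1 also has a carbon chain on an oxygen on an aromatic ring and gives 68000 nM, a real number in this assay. On that single comparison, a modest shift towards stronger inhibition is expected, with the estimated step of an at least 1.4-fold lower number from compound 2 to compound 3 (0.15 log units; that floor lies within the scatter). A result at the limit again would not be surprising. For compound 3 the expected value is 70000 nM, with an estimated range of 25000 nM to 150000 nM.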

Compound 3, half-maximal inhibitory concentration: > 100000 nM
Compound 3 was reported as a limit (the forecaster's own chance of this, stated with the estimate: 45%); at least 1.4-fold (0.15 log units) between middle value and limit.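

In this assay compound 3 gives > 100000 nM, a limit and not a number. Compound 2 is also at a limit, so no step can be read between compound 2 and compound 3, and the pair adds only this: the limit of > 100000 nM in this assay, at which 2 of the 3 values shown sit.

The compounds shown leave open how large the change from hydroxy to (but-3-en-1-yl)oxy is, and in which direction it runs.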